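The compounds below may be only part of what the source reports. "The series", "measured", "known", "first", "only" and "open" are said of these compounds alone.

Compound 1 `O=C(Nn1c(-c2cccc([N+](=O)[O-])c2)nc2c(-c3ccco3)n[nH]c2c1=O)c1cccnc1` gives -0.61% in a functional assay on SK-OV-3 cells (Homo sapiens) for cytotoxicity, read by sulforhodamine B assay, with a stated time of 2 days, tested at 100 uM; on this read-out higher numbers stand for more inhibition at the one concentration tested (going by the name of the read-out) and lower numbers for less inhibition.
Compound 2 `O=C(Nn1c(-c2cccc([N+](=O)[O-])c2)nc2c(-c3ccc(Cl)cc3)n[nH]c2c1=O)c1ccccc1` gives 86.8% in this assay.

Among the measured compounds shown here, of the two measured compounds, compound 2 stands highest in this assay; its only neighbour, compound 1, lies far lower, a gap well beyond the scatter. For the measured compounds named here, compound 1 and compound 2 differ at two places at once, so their values show only that the pair spans nearly the whole range of the read-out, not which change accounts for it.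

Compound 3 `O=C(Nn1c(-c2cccc([N+](=O)[O-])c2)nc2c(-c3ccco3)n[nH]c2c1=O)c1ccccc1` is the next step from compound 2: furan-2-yl in place of 4-chlorophenyl on an aromatic carbon. With this change compound 3 carries the same furan-2-yl group as compound 1 while the rest of compound 2 is kept. Going by the values given here, no single-change step between measured compounds exists, so the size of the step can only be judged from the two values. A large fall in this assay is expected, because compound 1 with its furan-2-yl gives -0.61%. The step expected is a number 61.8 percentage points lower from compound 2 to compound 3 (beyond the scatter). Compound 3 is estimated at 25%, with a range from 0% to 70%.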

Compound 3, a percentage reported as inhibition, at one concentration (the size of the read-out at that concentration, not a potency): 17.9%
Beside the measured number, compound 3's estimate is 7.1 percentage points above it, within the range that was stated.
By their numbers in this assay, from the lowest: compound 1; then compound 3; then compound 2.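

With only one place changed, furan-2-yl in place of 4-chlorophenyl on an aromatic carbon gives a number 68.9 percentage points lower from compound 2 to compound 3 (beyond the scatter) in this assay, so the group at this position alone accounts for much of the gap that the first pair left unassigned. The carbonyl carbon also matters, though by a modest step: phenyl in place of pyridin-3-yl there gives a number 18.5 percentage points higher from compound 1 to compound 3 (beyond the scatter). Nothing measured here accounts for either step.

The compounds shown leave open whether the fall follows the loss of the chlorine or the change of ring, since both change together, and where a 4-methoxyphenyl or thiophen-2-yl group would stand at this position. They also leave open how pyridin-3-yl on the carbonyl carbon would read alongside 4-chlorophenyl.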